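The compounds below may be only part of what the source reports. "The series", "measured", "known", "first", "only" and "open" are said of these compounds alone.

Compound 1 `COc1ncc(-c2ccc3ncnc(N[C@H]4CCCN(C(=O)C(F)(F)F)C4)c3c2)cc1C#N`, compound 2 `COc1ncc(-c2ccc3ncnc(N[C@H]4CCCN(C(=O)CCBr)C4)c3c2)cc1C#N` and compound 3 `COc1ncc(-c2ccc3ncnc(N[C@H]4CCCN(C(=O)CCl)C4)c3c2)cc1C#N` were tested in a functional assay on SU-DHL-6 cells (Homo sapiens) for antiproliferative activity, read by MTT assay; on this read-out higher numbers stand for weaker inhibition and lower numbers for stronger inhibition. Compound 1 gives 210 nM; compound 2 gives 15 nM; compound 3 gives 380 nM.

Compound 1 stands second highest of these three numbers, nearest to compound 3 and furthest from compound 2. Compound 4 `COc1ncc(-c2ccc3ncnc(N[C@H]4CCCN(C(=O)c5cccnc5)C4)c3c2)cc1C#N` differs from compound 1 in one place: pyridin-3-yl in place of trifluoromethyl on a carbonyl carbon. Two measured steps alter the same carbonyl carbon: a 14-fold lower number from compound 1 to compound 2 (1.15 log units; beyond the scatter), while a 1.8-fold higher number from compound 1 to compound 3 (0.26 log units; within the scatter). Neither brings in a ring, so they bear on compound 4 only by showing that changes at this position have given both a large fall and a step within the scatter. Compound 4 is therefore expected to sit close to compound 1, with no step beyond the scatter, a 1.4-fold higher number from compound 1 to compound 4 (0.15 log units; within the scatter). The estimate for compound 4 is 300 nM, ranging from 90 nM to 1000 nM.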

Compound 4, half-maximal inhibitory concentration: 120 nM
Compound 4: middle estimate off by 2.5-fold (0.40 log units), on the high side; measured number inside the range.
By their numbers in this assay, from the lowest: compound 2; then compounds 4, 1 and 3 (each within the scatter of the next, the first and the last beyond it).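

In this assay, among these compounds, the carbonyl carbon now carries a ring for the first time, and pyridin-3-yl is accepted there, with a 1.8-fold lower number from compound 1 to compound 4 (0.24 log units; within the scatter), while it clearly improves on chloromethyl, with a 3.2-fold lower number from compound 3 to compound 4 (0.50 log units; beyond the scatter). It does not match 2-bromoethyl, however, with an 8.0-fold higher number from compound 2 to compound 4 (0.90 log units; beyond the scatter), so compound 2 keeps the lowest number of the four. Still open, on these data alone, is whether the ring nitrogen matters, which a phenyl group at this carbonyl carbon would address, and whether a 2-chloroethyl chain would match 2-bromoethyl. No available evidence bears on these steps.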